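Spiro-fused pyranochromenone series: variation at the ring amide nitrogen

The source may hold more compounds than are shown below. What is called first, only, known or untested is meant among the compounds shown, and "the series" means these compounds.

Measured compounds in a functional assay on PC-3 cells (Homo sapiens) for antiproliferative activity, read by MTT assay, with a stated time of 48 h; on this read-out lower numbers stand for stronger inhibition and higher numbers for weaker inhibition:
- compound 1 `CN1C(=O)C2(C(C#N)=C(N)Oc3cc4oc(-c5ccccc5)cc(=O)c4c(O)c32)c2ccccc21`, reported only as the limit > 50000 nM
- compound 2 `N#CC1=C(N)Oc2cc3oc(-c4ccccc4)cc(=O)c3c(O)c2C12C(=O)N(c1ccccc1)c1ccccc12`, reported only as the limit > 50000 nM

Compound 2 stands on no number in this assay. Its value is a limit, and it shares that limit with compound 1, so the step that the two limits leave unreadable from compound 1 to compound 2 cannot be sized; both sit at the limit of > 50000 nM in this assay, at which 2 of the 2 values shown sit.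

Compound 3 `CC(C)(C)OC(=O)CN1C(=O)C2(C(C#N)=C(N)Oc3cc4oc(-c5ccccc5)cc(=O)c4c(O)c32)c2ccccc21` carries the change ((tert-butoxycarbonyl)methyl in place of phenyl on an amide-type nitrogen in a ring). For the measured compounds named here, the only measured step at this position, from compound 1 to compound 2, is unreadable, so nothing here indicates that a change on this nitrogen moves the read-out. Compound 3 is therefore expected to remain at the limit, giving no readable step that the limit leaves unreadable from compound 2 to compound 3 beyond the scatter. The estimate for compound 3 is 60000 nM, with a range from 15000 nM to 200000 nM, most likely reported again as a limit.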

Compound 3, half-maximal inhibitory concentration: > 50000 nM
Compound 3 was reported as a limit (the forecaster's own chance of this, stated with the estimate: 75%); the middle value lies beyond the limit too.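

Neither step to compound 3, from compound 1 or from compound 2, can be read in this assay, as all three compounds share one limit: the limit of > 50000 nM in this assay, at which 3 of the 3 values shown sit.

The compounds shown leave open whether any group on the amide-type nitrogen in a ring moves the read-out to a measurable value.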